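Swapping the aryl group in a series held at limits

The source may hold more compounds than are shown below. What is called first, only, known or untested is meant among the compounds shown, and "the series" means these compounds.

In a functional assay on HeLa cells (Homo sapiens) for inhibition, read by CCK-8 assay, with a stated time of 48 h (a lower number here means a stronger inhibitor, a higher number a weaker inhibitor), compound 1 `O=C(NCCNS(=O)(=O)c1sccc1-c1ccccc1Oc1ccc(O)c(O)c1)Nc1cc(Cl)cc(Cl)c1` reads > 50000 nM, which is a limit and not a number. Compound 2 `Cc1ccc(-c2ccsc2S(=O)(=O)NCCNC(=O)Nc2ccc([N+](=O)[O-])cc2)c(Oc2ccc(O)c(O)c2)c1` reads > 20000 nM, which is also a limit. Both values shown for the series are therefore limits, and neither gives a number to anchor it.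

Compound 3 `Cc1ccc(-c2ccsc2S(=O)(=O)NCCNC(=O)Nc2cc(Cl)cc(Cl)c2)c(Oc2ccc(O)c(O)c2)c1` has 3,5-dichlorophenyl in place of 4-nitrophenyl on an amide-type nitrogen. Going by the values given here, no measured step exists to size this change. The only reference for it is compound 2 at > 20000 nM, so no step beyond the scatter is expected in this assay, and another limit is a likely report. The expected change is a step that the limit leaves unreadable from compound 2 to compound 3. For compound 3 the estimated value is 30000 nM, with an expected range of 10000 nM to 80000 nM.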

Compound 3, half-maximal inhibitory concentration: 6500 nM
Beside the measured number, compound 3's estimate is 4.6-fold (0.66 log units) above it, and the stated range ends above it.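

In this assay, going by these compounds alone, compound 3 gives 6500 nM, the only value shown that is a number and not a limit. Replacing 4-nitrophenyl with 3,5-dichlorophenyl on an amide-type nitrogen brings an at least 3.0-fold lower number from compound 2 to compound 3 (0.48 log units; beyond the scatter), so this position does register a change of aryl group. With 3,5-dichlorophenyl held, methyl in place of hydrogen on an aromatic carbon brings an at least 7.6-fold lower number from compound 1 to compound 3 (0.88 log units; beyond the scatter), so a second place on the shared core also moves the read-out.

Going by these compounds, the step from compound 2 gives only a minimum size because compound 2 stands at a limit: the limit of > 20000 nM in this assay, at which 1 of the 3 values shown sits. Still open is how a plain phenyl or a phenyl carrying a carboxylic acid would read on that nitrogen, and whether the methyl step holds with 4-nitrophenyl in place.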